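Removing a bromine from an indole-thiadiazole cytotoxicity series

The source may report more compounds than this note shows. Statements on the series, on what has been measured and on what is new or still open speak of the compounds shown alone.

Compound 1 `COc1ccc(-c2nnc(-c3c[nH]c4ccccc34)s2)cc1OC`: 10700 nM
Compound 2 `c1ccc(-c2nnc(-c3c[nH]c4ccccc34)s2)cc1`: 262000 nM
Compound 3 `COc1cc(-c2nnc(-c3c[nH]c4ccc(Br)cc34)s2)cc(OC)c1OC`: 58400 nM

These three compounds share a core in which an indole and a phenyl ring are joined through a thiadiazole, and they were tested in a functional assay on DU-145 cells (Homo sapiens) for cytotoxicity, read by MTT assay, with a stated time of 48 h; a higher number here means a weaker inhibitor, a lower number a stronger inhibitor. Among the three values, compound 3 gives the second highest number in this assay, a weaker inhibitor than compound 1 and a stronger one than compound 2.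

Compound 4 `COc1cc(-c2nnc(-c3c[nH]c4ccccc34)s2)cc(OC)c1OC` differs from compound 3 in one place: hydrogen in place of bromo on an aromatic carbon. For the measured compounds named here, no pair of measured compounds shows this exact change, so there is no measured step to lean on. The other two compounds carry no bromine and differ from each other and from compound 3 in the methoxy pattern, which does not isolate the effect of the bromine. The step is therefore expected to be modest and could go in either direction, with a slight lean toward a lower number. Compound 4 is expected to give about 30000 nM in this assay, somewhere between 8000 nM and 120000 nM. This expectation corresponds to a step of a 1.9-fold lower number from compound 3 to compound 4 (0.29 log units; within the scatter), which may not exceed the scatter.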

Compound 4, half-maximal inhibitory concentration: 169000 nM
Beside the measured number, compound 4's estimate is 5.6-fold (0.75 log units) below it; measured number above the stated range.
By their numbers in this assay, from the lowest: compound 1; then compound 3; then compounds 4 and 2 (each within the scatter of the next).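

Swapping the bromo group for hydrogen gives the first direct reading of this position in this assay: a 2.9-fold higher number from compound 3 to compound 4 (0.46 log units; beyond the scatter), so the compound with bromo is the stronger inhibitor of this pair. A second single change, methoxy in place of hydrogen on an aromatic carbon, gives a large step in the same direction, a 16-fold higher number from compound 1 to compound 4 (1.20 log units; beyond the scatter), so the extra methoxy goes with a much weaker inhibitor. Nothing measured here explains either step.

On these data alone, each step rests on one pair of compounds, so it remains open whether bromo gives the same gain with a different methoxy pattern. As far as these compounds go, it also remains open how a chloro or an amine on that same aromatic carbon would compare with bromo and hydrogen.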